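The source may report more compounds than this note shows. Statements on the series, on what has been measured and on what is new or still open speak of the compounds shown alone.

Measured so far:
compound 1 `Cc1ccc(NC(=O)Nc2ccc(-c3nc(NCCCN(C)C)c4sc(Cl)c(Cl)c4n3)cc2)cc1` gives 4980 nM
compound 2 `CN(C)CCNc1nc(-c2ccc(NC(=O)Nc3ccccc3Cl)cc2)nc2c(Cl)c(Cl)sc12` gives 1350 nM
compound 3 `CCN(CC)CCCNc1nc(-c2ccc(NC(=O)Nc3ccccc3)cc2)nc2c(Cl)c(Cl)sc12` gives 1780 nM

These numbers come from a functional assay on MDA-MB-231 cells (Homo sapiens) for cytotoxicity, read by MTT assay, with a stated time of 72 h; a lower number here means a stronger inhibitor, a higher number a weaker inhibitor. Compound 3 stands second highest of the three: compound 2 lies within the usual scatter of it, while compound 1 lies beyond the scatter with a higher number. Compound 4 `CCN(CC)CCCNc1nc(-c2ccc(NC(=O)Nc3ccc(Cl)cc3Cl)cc2)nc2c(Cl)c(Cl)sc12` is not yet measured. It differs from compound 3 in one place: 2,4-dichlorophenyl in place of phenyl on an amide-type nitrogen. Going by the values given here, no measured pair differs in just this way, so the data give no step of this kind. Because compound 2 also carries chlorine on that phenyl and gives 1350 nM, the expected step is a 1.4-fold lower number from compound 3 to compound 4 (0.14 log units; within the scatter), nothing beyond the scatter. Compound 4 is estimated at 1300 nM, between 500 nM and 3500 nM.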

Compound 4, half-maximal inhibitory concentration: 3940 nM
The estimate for compound 4 lay 3.0-fold (0.48 log units) below the measured number; measured number outside the range, above it.
By their numbers in this assay, from the lowest: compounds 2 and 3 (each within the scatter of the next); then compounds 4 and 1 (each within the scatter of the next).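

In this assay, going by these compounds alone, this is the first pair that isolates a change on the phenyl attached to the amide-type nitrogen, and 2,4-dichlorophenyl in place of phenyl gives a 2.2-fold higher number from compound 3 to compound 4 (0.35 log units; beyond the scatter). In this one pair, adding the two chlorines makes the compound a weaker inhibitor, not a stronger one. Nothing measured here gives a reason for this shift. On these data alone, with the rest of compound 3 kept, the effect of a single chlorine on that phenyl stays open. So does the effect of a methoxy group or a carboxylic acid there.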